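A few compounds are considered here, and "the series" means these few. Any claim that something is new, unique, unknown or untested is made for them only; others in the source may bear on it.

Compound 1 `O=C(OC1CCC(CN2CCN(c3cc(=O)c4cc(C(F)(F)F)cc([N+](=O)[O-])c4s3)CC2)CC1)c1cccc(C(F)(F)F)c1` is one of three compounds with a shared core that were examined in an ADME assay on Vero cells (Chlorocebus sabaeus) for cytotoxicity, read by MTT assay, with a stated time of 48 h; on this read-out higher numbers stand for weaker inhibition and lower numbers for stronger inhibition. In this assay compound 1 gives > 64 ug/mL, which is a limit of the assay and not a number. Compound 3 `COc1ccccc1C(=O)OC1CCC(CN2CCN(c3cc(=O)c4cc(C(F)(F)F)cc([N+](=O)[O-])c4s3)CC2)CC1`, which carries 2-methoxyphenyl in place of 3-(trifluoromethyl)phenyl on a carbonyl carbon, gives > 64 ug/mL in this assay, again a limit. Compound 2 `O=c1cc(N2CCN(CC3CCC(NS(=O)(=O)c4ccccc4)CC3)CC2)sc2c([N+](=O)[O-])cc(C(F)(F)F)cc12` carries (phenylsulfonyl)amino on a saturated ring carbon where compound 3 carries ((2-methoxyphenyl)carbonyl)oxy. In this assay compound 2 gives > 64 ug/mL, also a limit. The step that the two limits leave unreadable from compound 1 to compound 3 and the step that the two limits leave unreadable from compound 2 to compound 3 are thus both of a size that cannot be read, since all three values sit at the limit of > 64 ug/mL in this assay, at which 3 of the 3 values shown sit.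

Compound 4 `O=C(OC1CCC(CN2CCN(c3cc(=O)c4cc(C(F)(F)F)cc([N+](=O)[O-])c4s3)CC2)CC1)c1cccc(F)c1` has not yet been measured; it differs from compound 1 by fluoro in place of trifluoromethyl on an aromatic carbon. Going by the values given here, the only measured step that starts from compound 1 is the unreadable one to compound 3, and this particular change has no measured counterpart within the set. Nothing in the three values argues for a step in either direction beyond the scatter. Compound 4 is therefore expected to give about 100 ug/mL (from 64 ug/mL to 200 ug/mL) in this assay, which would mean an expected step that the limit leaves unreadable from compound 1 to compound 4.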

Compound 4, half-maximal inhibitory concentration: > 64 ug/mL
Compound 4 was reported as a limit (the forecaster's own chance of this, stated with the estimate: 85%); the middle value is on the limit's open side.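

In this assay compound 4 gives > 64 ug/mL, which is a limit and not a number. No step to compound 4 from compound 1, compound 2 or compound 3 can be read, since all four values sit together: the limit of > 64 ug/mL in this assay, at which 4 of the 4 values shown sit.

The compounds shown leave open how large the effect of any of these changes is in this assay.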